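Chloro for ethyl on the compound 2 scaffold

This account rests on a few compounds, and the source may have more. Where it says the series, first, only, none or still open, it means among the compounds named here.

Values so far in a functional assay on HeLa cells (Homo sapiens) for inhibition, read by CCK-8 assay, with a stated time of 72 h, tested at 8 uM (on this read-out lower numbers stand for less inhibition of growth and higher numbers for more inhibition of growth at the one concentration tested), follow.
Compound 1 `Nc1ccccc1NC(=O)/C=C/c1ccc(CSc2ccc(Cl)cc2)cc1` gives 17.3%
Compound 2 `CCc1ccc(SCc2ccc(C(=O)Nc3ccccc3N)cc2)cc1` gives 71%
Compound 3 `COC(=O)c1ccccc1SCc1ccc(C(=O)Nc2ccccc2N)cc1` gives 55.5%

Compound 2 (71%) holds the highest of the three numbers, and both compound 3 (55.5%) and compound 1 (17.3%) lie lower, beyond the scatter. Still unmeasured, compound 4 `Nc1ccccc1NC(=O)c1ccc(CSc2ccc(Cl)cc2)cc1` carries chloro in place of ethyl on an aromatic carbon, para to a large group (chloro in place of ethyl on an aromatic carbon). Among the compounds with values here, no two measured compounds differ at one place alone, so the data give no direct size for this change. With compound 2 (71%) as the closest reference, a small fall in this assay is expected, and no large collapse is assumed. The expected step of a number 9 percentage points lower from compound 2 to compound 4 (within the scatter) is estimated to stay within the scatter. For compound 4 the estimated value is 62%, with an expected range of 42% to 80% around it.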

Compound 4, percent growth inhibition at one concentration: 51.4%
Compound 4: middle estimate off by 10.6 percentage points, on the high side, within the range that was stated.
By their numbers in this assay, from the lowest: compound 1; then compounds 4 and 3 (each within the scatter of the next); then compound 2.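

In this assay, within the data shown here, the change from 4-ethylphenyl to 4-chlorophenyl gives the first comparison that differs at one place alone, and the reading is a number 19.6 percentage points lower from compound 2 to compound 4 (beyond the scatter), a modest step. The substituent on this aromatic carbon, para to a large group, therefore matters to the read-out, although with chloro in place of ethyl compound 4 still gives 51.4% and does not lose inhibition entirely. Nothing available explains the size or direction of this step.

A single pair cannot show whether a methoxy group, an amine or a longer chain on this carbon would give a number nearer to that of compound 2 or a lower one. It also leaves open whether chloro in place of ethyl would give a step of similar size on the core of compound 1.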